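The source may report more compounds than this note shows. Statements on the series, on what has been measured and on what is new or still open speak of the compounds shown alone.

Measured in an ADME assay on HeLa cells (Homo sapiens) for cytotoxicity, read by crystal violet staining, with a stated time of 72 h; on this read-out lower numbers stand for higher toxicity in this test and higher numbers for lower toxicity in this test:
- Compound 1 `CCOC(=O)c1cc(CCCOc2c(C)cc(-c3noc(C(F)(F)F)n3)cc2C)on1`: 17200 nM
- Compound 2 `CCOC(=O)c1cc(CCCOc2ccc(-c3noc(C(F)(F)F)n3)cc2C)on1`: 35100 nM

Of these two, compound 1 holds the lower number, at 17200 nM. Compound 3 `Cc1cc(-c2noc(C(F)(F)F)n2)cc(C)c1OCCCc1cc(-c2ccc(OC(F)(F)F)cc2)no1` is the next to be tested. It departs from compound 1 by 4-(trifluoromethoxy)phenyl in place of ethoxycarbonyl on an aromatic carbon.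

Within the data shown here, only one measured step is available, a 2.0-fold higher number from compound 1 to compound 2 (0.31 log units; beyond the scatter). It is modest and comes from hydrogen in place of methyl on an aromatic carbon, a change at a different site. Among the measured compounds shown here, it therefore says little about this exchange, and no measured step covers the larger group. In this assay, as far as these compounds go, no step beyond the scatter is expected, and the direction stays open. The expected step is a 1.0-fold higher number from compound 1 to compound 3 (0.02 log units; within the scatter). For compound 3 the estimated value is 18000 nM, with an expected range from 6000 nM to 55000 nM.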

Compound 3, half-maximal cytotoxic concentration: > 100000 nM
Compound 3: no number, only a limit (the forecaster's own chance of this, stated with the estimate: 25%); middle value at least 5.5-fold (0.74 log units) from the limit.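

Compound 1 and compound 2 differed only by a methyl on an aromatic carbon, and they left the ethoxycarbonyl untouched. Compound 3 shows that the place on the five-membered aromatic ring, next to the ring nitrogen, also counts in this assay: exchanging ethoxycarbonyl for 4-(trifluoromethoxy)phenyl there gives an at least 5.8-fold higher number from compound 1 to compound 3 (0.76 log units; beyond the scatter), so this large aromatic group does not raise toxicity in this test. The reading for compound 3 is a limit and not a number, so the full size of this step cannot be told: the limit of > 100000 nM in this assay, at which 1 of the 3 values shown sits.

The compounds shown do not separate the effect of the phenyl ring from that of its trifluoromethoxy group or from the loss of the ethoxycarbonyl. As far as these compounds go, how an unsubstituted phenyl, a carboxylic acid or an amide at this place would read in this assay remains open.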